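Cytotoxicity in BJ cells: cyanophenyl for methylphenyl

The source may report more compounds than this note shows. Statements on the series, on what has been measured and on what is new or still open speak of the compounds shown alone.

In an ADME assay on BJ cells (Homo sapiens) for cytotoxicity, with a stated time of 72 h (a higher number here means that more compound is needed for the effect, a lower number that less compound is needed), compound 2 `Cc1cccc(-c2nc3c(c(C)nn3-c3ccccc3)c(-c3ccccc3O)c2C#N)c1` gives only a limit, > 20000 nM. Compound 1 `CCc1ccc(-c2nc3c(c(C)nn3-c3ccccc3)c(-c3ccc(O)cc3)c2C#N)cc1` likewise returns a limit in this assay, > 20000 nM. Among the measured compounds shown here, the whole picture is the limit of > 20000 nM in this assay, at which 2 of the 2 values shown sit, so no step between measured compounds can be sized. Compound 3 `Cc1nn(-c2ccccc2)c2nc(-c3ccc(C#N)cc3)c(C#N)c(-c3ccccc3O)c12` differs from compound 2 by 4-cyanophenyl in place of 3-methylphenyl on an aromatic carbon. For the measured compounds named here, no measured step bears on this change, and with both known values stopping at the limit the expected step is a step that the limit leaves unreadable from compound 2 to compound 3, none beyond the scatter. For compound 3 the estimate in this assay is 30000 nM, range 12000 nM to 100000 nM, most likely again reported as a limit.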

Compound 3, half-maximal effective concentration: > 20000 nM
Compound 3: a limit, no number; the forecaster's own chance of this, stated with the estimate: 80%; the middle value is on the limit's open side.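

Compound 3 gives only a limit, > 20000 nM. No step can be read between compound 2 and compound 3. The compounds shown leave open at what concentration any of them produces cytotoxicity in this assay.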